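The source may hold more compounds than are shown below. What is called first, only, known or untested is meant among the compounds shown, and "the series" means these compounds.

Compound 1 `COc1ccc(S(=O)(=O)NCCCNc2nccc(-c3c(-c4cccc(F)c4)nc4sccn34)n2)cc1`: 8980 nM
Compound 2 `O=S(=O)(NCCCNc1nccc(-c2c(-c3cccc(F)c3)nc3sccn23)n1)c1ccc(Cl)cc1`: 8450 nM
Compound 3 `O=C(NCCNc1nccc(-c2c(-c3cccc(F)c3)nc3sccn23)n1)c1ccc(Cl)cc1`: 8160 nM

All three were measured in a functional assay on SK-MEL-28 cells (Homo sapiens) for cytotoxicity, read by MTT assay; a lower number here means a stronger inhibitor, a higher number a weaker inhibitor. Compound 3 gives the lowest of the three numbers, yet the steps of a 1.1-fold lower number from compound 1 to compound 2 (0.03 log units; within the scatter) and a 1.0-fold lower number from compound 2 to compound 3 (0.02 log units; within the scatter) are both within the scatter, so the three stand level. Compound 4 `O=C(NCCCNc1nccc(-c2c(-c3cccc(F)c3)nc3sccn23)n1)c1ccc(Cl)cc1` is not yet measured; it differs from compound 3 by (((4-chlorophenyl)carbonyl)amino)methyl in place of ((4-chlorophenyl)carbonyl)amino on a saturated chain carbon, two bonds along the chain from a nitrogen on an aromatic ring. Among the compounds with values here, no measured step alters the chain alone. Within the data shown here, the one step that touched the chain, a 1.0-fold lower number from compound 2 to compound 3 (0.02 log units; within the scatter), also exchanged the group at its end and stayed within the scatter, and compounds 1 and 2, which carry the same chain length as compound 4, sit close to compound 3. Hence no step beyond the scatter is expected: a 1.0-fold higher number from compound 3 to compound 4 (0.02 log units; within the scatter). Compound 4 is estimated at 8500 nM, between 4000 nM and 18000 nM.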

Compound 4, half-maximal inhibitory concentration: > 20000 nM
Compound 4: only a limit was reported; the forecaster's own chance of this, stated with the estimate: 5%; middle value at least 2.3-fold (0.37 log units) from the limit.
By their numbers in this assay, from the lowest: compounds 3, 2 and 1 (each within the scatter of the next). At a limit, above all of these: compound 4.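

Compound 4 gives only a limit of the assay, not a number: the limit of > 20000 nM in this assay, at which 1 of the 4 values shown sits. Lengthening the chain alone gives an at least 2.4-fold higher number from compound 3 to compound 4 (0.38 log units; beyond the scatter), so this position does respond to chain length when the chain ends in the carbonyl. On that same longer chain, the carbonyl in place of the sulfonyl gives an at least 2.3-fold higher number from compound 2 to compound 4 (0.37 log units; beyond the scatter), and with the methoxy-bearing sulfonyl it gives an at least 2.2-fold higher number from compound 1 to compound 4 (0.34 log units; beyond the scatter), so the two linking groups are not interchangeable here. Open, as far as these compounds go, is how a sulfonyl fares on the shorter chain of compound 3. Also open, from the compounds shown here alone, is what a still longer chain, or an amine in place of the carbonyl, would do.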